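Aryl Swap on the Ring Amine Nitrogen: Compound 2 to Compound 3

A few compounds are considered here, and "the series" means these few. Any claim that something is new, unique, unknown or untested is made for them only; others in the source may bear on it.

Measured so far:
compound 1 `CCCS(=O)(=O)N1CC=C(c2ccc3c(c2)CC(C2CCN(C(=O)OC4CCCCC4)CC2)O3)CC1`: 51 nM
compound 2 `CCCS(=O)(=O)N1CC=C(c2ccc3c(c2)CC(C2CCN(c4ncc(C5CC5)cn4)CC2)O3)CC1`: 67 nM

Within the data shown here, compound 2 sits at one end of the two measured numbers in a functional assay on HEK293 cells for agonist activity at Glucose-dependent insulinotropic receptor (Homo sapiens), read by cAMP accumulation, with a stated time of 60 min (on this read-out higher numbers stand for an effect only at larger amounts of compound and lower numbers for an effect already at smaller amounts), but the only other number, that of compound 1, is not separated from it: a 1.3-fold higher number from compound 1 to compound 2 (0.12 log units; within the scatter). The two compounds are therefore indistinguishable on this read-out.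

Compound 3 `CCCS(=O)(=O)N1CC=C(c2ccc3c(c2)CC(C2CCN(c4ccc(C(F)(F)F)cn4)CC2)O3)CC1` is the next member. It differs from compound 2 in one place: 5-(trifluoromethyl)pyridin-2-yl in place of 5-cyclopropylpyrimidin-2-yl on an amine nitrogen in a ring. Among the measured compounds shown here, the single measured step, from compound 1 to compound 2, also exchanged the group on that same amine nitrogen in a ring and stayed within the scatter, as a 1.3-fold higher number from compound 1 to compound 2 (0.12 log units; within the scatter) shows. That step exchanged a carbamate-type group for a heteroaryl group, whereas the present change exchanges one heteroaryl group for another, so the precedent is indirect. With nothing pointing in either direction, the expected step of a 1.0-fold higher number from compound 2 to compound 3 (0.02 log units; within the scatter) is none beyond the scatter. Compound 3 is accordingly estimated at 70 nM in this assay, with a range from 30 nM to 170 nM.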

Compound 3, half-maximal effective concentration: 34 nM
The estimate for compound 3 lay 2.1-fold (0.31 log units) above the measured number; the range from low to high includes it.
By their numbers in this assay, from the lowest: compounds 3, 1 and 2 (each within the scatter of the next).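

In this assay, among these compounds, the first exchange of one heteroaryl group for another on this amine nitrogen in a ring gives a 2.0-fold lower number from compound 2 to compound 3 (0.29 log units; within the scatter), which stays within the scatter even though the six-membered aromatic ring with 2 hetero atoms gives way to one with 1 hetero atom and the three-membered ring of carbon only is gone. Against the cyclohexyloxycarbonyl group, 5-(trifluoromethyl)pyridin-2-yl gives a 1.5-fold lower number from compound 1 to compound 3 (0.18 log units; within the scatter), also within the scatter, so all three groups at this position, in compounds 1, 2 and 3, remain indistinguishable on this read-out, and none of the three goes against that. No supporting data bear on any reason for these numbers.

As far as these compounds go, whether a primary amine or a carboxylic acid in place of the trifluoromethyl group of compound 3 would move the number beyond the scatter stays open, as does the effect of an acetyl group on the same amine nitrogen in a ring. From the compounds shown here alone, all three compounds also share the propyl chain on the sulfonyl group, so the effect of a longer chain there remains open too.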